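A few compounds are considered here, and "the series" means these few. Any claim that something is new, unique, unknown or untested is made for them only; others in the source may bear on it.

Measured compounds:
Compound 1 `CCCCOc1nc(N)c2[nH]c(=O)n(Cc3ccccc3)c2n1` gives 0.1 mg/kg.
Compound 2 `Nc1ncnc2c1nc(O)n2Cc1ccc(F)cc1` gives 30 mg/kg.
Compound 3 `Cc1nc(N)c2nc(O)n(Cc3ccccc3)c2n1` gives 3 mg/kg.

These three values come from a functional assay on the whole organism for activation, with Mus musculus as the target; on this read-out lower numbers stand for an effect already at smaller amounts and higher numbers for an effect only at larger amounts of compound. Compound 3 stands second highest of the three numbers: compound 2 shows a higher number, and compound 1 a lower number, both gaps lying beyond the usual scatter. Compound 4 `CCCSc1nc(N)c2nc(O)n(Cc3ccccc3)c2n1` has not yet been measured in this assay. It differs from compound 3 in one place: propylsulfanyl in place of methyl on an aromatic carbon. For the measured compounds named here, no pair of measured compounds differs in exactly this way, so the size of the step cannot be read directly from a measured pair. Still, compound 1 carries a butoxy chain at the same kind of position and gives 0.1 mg/kg, while compound 3 with methyl gives 3 mg/kg. On that ground the step from methyl to a longer chain bearing a heteroatom is expected to lower the number, beyond the scatter, so that the expected step is a 6.0-fold lower number from compound 3 to compound 4 (0.78 log units; beyond the scatter). For compound 4 the estimate in this assay is therefore 0.5 mg/kg, with a range from 0.1 mg/kg to 3 mg/kg.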

Compound 4, minimum effective dose: 0.1 mg/kg
Compound 4: the middle estimate sits 5.0-fold (0.70 log units) above what was measured, within the range that was stated.
By their numbers in this assay, from the lowest: compounds 1 and 4 (each within the scatter of the next); then compound 3; then compound 2.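

In this assay, for the compounds shown here, the aromatic carbon between two ring nitrogen atoms proves highly responsive to a single change: propylsulfanyl in place of methyl gives a 30-fold lower number from compound 3 to compound 4 (1.48 log units; beyond the scatter), the first step at this position that can be read from one change alone. It also shows that a chain linked through sulfur can do as well here as one linked through oxygen, with compound 4 at 0.1 mg/kg and the butoxy-bearing compound 1 at the same printed value of 0.1 mg/kg. No measurement shown here accounts for the size of this step.

The compounds shown leave open whether the linking atom or the chain itself carries the effect. A plain butyl chain or a butylamino group at this position would bear on that question.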